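A few compounds are considered here, and "the series" means these few. Any claim that something is new, unique, unknown or untested is made for them only; others in the source may bear on it.

For the measured compounds named here, compound 2 `COc1cc(-c2cc(-c3ccc(Br)cc3)nc(-c3ccccc3)n2)cc(OC)c1OC` gives 4320 nM in a functional assay on HCT-116 cells (Homo sapiens) for inhibition, read by MTT assay, with a stated time of 48 h (a lower number here means a stronger inhibitor, a higher number a weaker inhibitor), the lowest of the two numbers measured so far. Going by the values given here, the only other measured compound, compound 1 `COc1cc(-c2cc(-c3ccc(N)cc3)nc(-c3ccccc3)n2)cc(OC)c1OC`, gives 12300 nM in this assay, and the one step between them, a 2.8-fold lower number from compound 1 to compound 2 (0.45 log units; beyond the scatter), came from bromo in place of amino on an aromatic carbon. Compound 3 `COc1cc(-c2cc(-c3ccccc3)nc(-c3ccccc3)n2)cc(OC)c1OC` carries the change (hydrogen in place of bromo on an aromatic carbon). Among the compounds with values here, the earlier step shows that what sits on this aromatic carbon matters, but no measured pair tells how bromo compares with hydrogen there, so the direction of the next step is open and only its likely size can be judged from the one modest step seen. The step expected here is a 1.6-fold higher number from compound 2 to compound 3 (0.21 log units; within the scatter). Compound 3 is therefore estimated at 7000 nM in this assay, with a range from 2500 nM to 20000 nM.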

Compound 3, half-maximal inhibitory concentration: 9950 nM
Estimate against measurement, compound 3: 1.4-fold (0.15 log units) below; measured number inside the range.
By their numbers in this assay, from the lowest: compound 2; then compounds 3 and 1 (each within the scatter of the next).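

In this assay, taking the bromo off the ring gives a 2.3-fold higher number from compound 2 to compound 3 (0.36 log units; beyond the scatter), so bromo now has a direct comparison with plain hydrogen on this carbon. Exchanging amino for hydrogen gives a 1.2-fold lower number from compound 1 to compound 3 (0.09 log units; within the scatter), so these two groups cannot be told apart in this assay. The earlier step from amino to bromo therefore now reads as a gain seen with bromo, and compound 2 stands as the strongest inhibitor of the three.

As far as these compounds go, whether this gain belongs to bromo alone, or would also appear with chloro, a methoxy group or a longer chain on the same carbon, stays open. No measurement shown here explains why bromo and hydrogen differ.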